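The source may hold more compounds than are shown below. What is called first, only, known or untested is meant among the compounds shown, and "the series" means these compounds.

Two compounds built on closely related cores have so far given no number in a functional assay for inhibition, with Homo sapiens as the target; on this read-out higher numbers stand for weaker inhibition and lower numbers for stronger inhibition. Compound 1 (`O=C(O)CCCCCCCCn1nc(-c2ccccc2)cc1-c1ccccc1`) reads > 66000 nM, which is a limit of the assay and not a number. Compound 2 (`CC(C)(C)OC(=O)COCCCCCCn1nc(-c2ccccc2)c(-c2ccccc2)c1-c1ccccc1`) reads > 62000 nM, and this too is a limit of the assay. Among the measured compounds shown here, compound 2 therefore has no measured potency, and no measured step links it to any other compound.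

Compound 3 (`CS(=O)(=O)NC(=O)CCCCCCCCn1nc(-c2ccccc2)c(-c2ccccc2)c1-c1ccccc1`) is the next to be tested. It differs from compound 2 as follows: 2-((methylsulfonyl)carbamoyl)ethyl in place of (tert-butoxycarbonyl)methoxy on a saturated chain carbon, six bonds along the chain from an aromatic nitrogen. In words, 2-((methylsulfonyl)carbamoyl)ethyl stands in place of (tert-butoxycarbonyl)methoxy on a saturated chain carbon, six bonds along the chain from an aromatic nitrogen.

With only limits to work from, any forecast is loose. A modest move towards stronger inhibition is expected, and a further limit would be no surprise. The expected change is an at least 2.0-fold lower number from compound 2 to compound 3 (0.31 log units; beyond the scatter). For compound 3 in this assay, the estimated value is 30000 nM, with an expected range of 3000 nM to 100000 nM.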

Compound 3, half-maximal inhibitory concentration: 5900 nM
The estimate for compound 3 lay 5.1-fold (0.71 log units) above the measured number, within the range that was stated.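

The exchange of (tert-butoxycarbonyl)methoxy for 2-((methylsulfonyl)carbamoyl)ethyl, on a saturated chain carbon, six bonds along the chain from an aromatic nitrogen, yields the first real number among these compounds in this assay, and the step is large: an at least 10-fold lower number from compound 2 to compound 3 (1.02 log units; beyond the scatter). Compound 2 reads only as a limit of the assay, so this step gives a minimum size and not an exact one: the limit of > 62000 nM in this assay, at which 1 of the 3 values shown sits. The leaving and entering groups match in heavy atoms and in hydrogen-bond acceptors, and the differences lie in the hydrogen-bond donor and the nitrogen and sulfur atoms that enter, but a single step cannot assign the gain to any one of these features.

From the compounds shown here alone, it remains open whether the gain depends on the (methylsulfonyl)carbamoyl end group itself or would also appear with a carboxylic acid or a tetrazole at the end of the chain on the core of compound 3. Going by these compounds, how a shorter or a longer chain carrying the same end group would read in this assay also remains open.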